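Adding a Chloro Group to Compound 2

The compounds below may be only part of what the source reports. "The series", "measured", "known", "first", "only" and "open" are said of these compounds alone.

Compound 1 `CCNC(=O)NCCC(=O)c1cc(Cl)ccc1N` and compound 2 `CC(=N)NCCC(=O)c1ccccc1N` were examined in an assay for inhibition of Nitric oxide synthase, inducible (Homo sapiens), read by ELISA, with a stated time of 30 min; a lower number here means a stronger inhibitor, a higher number a weaker inhibitor. In this assay compound 1 gives 100000 nM. For compound 2 the result in this assay is only a limit, > 1000000 nM. Compound 2 thus stands at the limit of this assay (the limit of > 1000000 nM in this assay, at which 1 of the 2 values shown sits). Compound 3 `CC(=N)NCCC(=O)c1cc(Cl)ccc1N` differs from compound 2 by chloro in place of hydrogen on an aromatic carbon. No measured step of this kind exists among these compounds, so no direction beyond the scatter in this assay can be drawn from them. Compound 3 is estimated at 300000 nM, expected between 60000 nM and 1000000 nM. The expected step of an at least 3.3-fold lower number from compound 2 to compound 3 (0.52 log units; beyond the scatter) rests only on that estimate.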

Compound 3, half-maximal inhibitory concentration: 25600 nM
Beside the measured number, compound 3's estimate is 12-fold (1.07 log units) above it, and the stated range ends above it.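

Chloro in place of hydrogen on the aromatic carbon para to an amino group gives a large change in this assay, with an at least 39-fold lower number from compound 2 to compound 3 (1.59 log units; beyond the scatter). With the chloro kept, the group on the amine nitrogen also matters, though more modestly, with a 3.9-fold lower number from compound 1 to compound 3 (0.59 log units; beyond the scatter). The size of the first step is open on one side, because compound 2 is only a limit: the limit of > 1000000 nM in this assay, at which 1 of the 3 values shown sits.

On these data alone, whether fluoro, bromo or methyl on this carbon would give a similar step remains open. So does the effect of chloro on another carbon of the aromatic ring.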